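Moving from a fluorophenyl to a bromopyridyl thiourea

A few compounds are considered here, and "the series" means these few. Any claim that something is new, unique, unknown or untested is made for them only; others in the source may bear on it.

Compound 1 `Nc1ccccc1NC(=O)c1ccc(NC(=S)NCc2ccccc2F)cc1` in an assay on isolated protein for inhibition of Nicotinamide phosphoribosyltransferase (Homo sapiens), read by fluorescence, with stated times of 5 min and 15 min (on this read-out lower numbers stand for stronger inhibition and higher numbers for weaker inhibition), gives only an assay limit, > 2000 nM.
Compound 2 `Nc1ccccc1NC(=O)c1ccc(NC(=O)/C(Cl)=C(\Cl)c2cccnc2)cc1` in this assay likewise gives only a limit, > 2000 nM.
Compound 3 `Nc1ccccc1NC(=O)c1ccc(NC(=O)NCc2ccc(Cl)nc2)cc1` in this assay also gives only a limit, > 2000 nM.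

Every value shown is a limit rather than a number, so compound 1 cannot be placed above or below its companions; all three sit together at the limit of > 2000 nM in this assay, at which 3 of the 3 values shown sit. The step of interest leads from compound 1 to compound 4 `Nc1ccccc1NC(=O)c1ccc(NC(=S)NCc2cncc(Br)c2)cc1`, in which the change is 5-bromopyridin-3-yl in place of 2-fluorophenyl on a saturated chain carbon bound to an amide-type nitrogen. The thiourea link and the shared core of compound 1 are kept. Within the data shown here, no step between measured compounds is available to show how such a change behaves here, and three limits give no foothold for a trend. The expectation for the step from compound 1 to compound 4 is therefore one of no change beyond the scatter, a step that the limit leaves unreadable from compound 1 to compound 4, with a considerable chance that the result is once more only a limit. Compound 4 is accordingly estimated at 4000 nM in this assay, within a range from 1500 nM to 15000 nM.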

Compound 4, half-maximal inhibitory concentration: > 2000 nM
Compound 4: only a limit was reported; the forecaster's own chance of this, stated with the estimate: 75%; the middle value lies beyond the limit too.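

Compound 4, like compound 1, gives only a limit in this assay, so no step can be read between the two, and the values offer no comparison: the limit of > 2000 nM in this assay, at which 4 of the 4 values shown sit.

The compounds shown leave open whether 5-bromopyridin-3-yl and 2-fluorophenyl on a saturated chain carbon bound to an amide-type nitrogen differ at all in this inhibition, and which structural change would yield a readable number.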